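A few compounds are considered here, and "the series" means these few. Any claim that something is new, unique, unknown or untested is made for them only; others in the source may bear on it.

In a functional assay on RXF 393 cells (Homo sapiens) for inhibition, read by sulforhodamine B assay, with a stated time of 48 h (on this read-out lower numbers stand for stronger inhibition of growth and higher numbers for weaker inhibition of growth), three compounds built on one shared core have been measured. Compound 1 `COc1cc(-c2nn(-c3cccc(NC(=O)Nc4cc(C(F)(F)F)cc(C(F)(F)F)c4)c3)cc2-c2ccncc2)ccc1Cl` gives 2060 nM. Compound 2 `COc1cc(-c2nn(-c3cccc(NC(=O)c4cccc(C(F)(F)F)c4)c3)cc2-c2ccncc2)ccc1Cl` gives 3150 nM. Compound 3 `COc1cc(-c2nn(-c3cccc(NC(=O)Nc4ccc(Cl)c(Cl)c4)c3)cc2-c2ccncc2)ccc1Cl` gives 2440 nM, the second highest of the three numbers; its nearest neighbour is compound 1 and its furthest is compound 2, and both gaps lie within the scatter of repeated measurements, so no order among the three can be read from them.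

Compound 4 `COc1cc(-c2nn(-c3cccc(NC(=O)Nc4cccc(C(F)(F)F)c4)c3)cc2-c2ccncc2)ccc1Cl` has not yet been measured. It differs from compound 3 in one place: 3-(trifluoromethyl)phenyl in place of 3,4-dichlorophenyl on an amide-type nitrogen. Among the compounds with values here, one measured step touches this exchange, the step of a 1.3-fold lower number from compound 2 to compound 3 (0.11 log units; within the scatter), which brings in the (3,4-dichlorophenyl)amino group in place of the 3-(trifluoromethyl)phenyl group on the carbonyl carbon; it mirrors the present exchange in the aryl part but also alters the attachment to the carbonyl carbon, so it bears on the question only loosely. Compound 1, which likewise carries trifluoromethyl substitution on the ring in question, sits within the scatter of compound 3. On this basis compound 4 is expected to move little, an estimated step of a 1.1-fold lower number from compound 3 to compound 4 (0.04 log units; within the scatter), with nothing beyond the scatter foreseen. The estimate for compound 4 in this assay is 2200 nM, within a range from 1100 nM to 4400 nM.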

Compound 4, concentration for total growth inhibition: 1940 nM
For compound 4 the middle estimate is 1.1-fold (0.05 log units) above the measured one, and the stated range covers the measured number.
By their numbers in this assay, from the lowest: compounds 4, 1, 3 and 2 (each within the scatter of the next).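

Within this assay, the exchange of 3,4-dichlorophenyl for 3-(trifluoromethyl)phenyl on the amide-type nitrogen now stands as a direct comparison, and a 1.3-fold lower number from compound 3 to compound 4 (0.10 log units; within the scatter) lies within the scatter, so these two aryl groups cannot be told apart at this position. Two further single changes around the same position also stay within the scatter: a 1.1-fold lower number from compound 1 to compound 4 (0.03 log units; within the scatter) comes with hydrogen in place of trifluoromethyl on an aromatic carbon, and a 1.6-fold lower number from compound 2 to compound 4 (0.21 log units; within the scatter) comes with (3-(trifluoromethyl)phenyl)amino in place of 3-(trifluoromethyl)phenyl on a carbonyl carbon, a comparison that keeps the same aryl group and so separates the attachment from the aryl change that the earlier step mixed together. None of these steps can be given a cause, as nothing measured here speaks to why the numbers sit so close.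

What the compounds shown leave open is whether this position tolerates anything outside the halogen-bearing and trifluoromethyl-bearing aryl groups, such as a ring carrying a carboxylic acid or an amine. They also leave open whether any change at this position, or elsewhere on the shared core, would move the number beyond the scatter.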